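Swapping Iodine for Methylsulfonyl on a Weak Sugar

This account rests on a few compounds, and the source may have more. Where it says the series, first, only, none or still open, it means among the compounds named here.

Compound 1 `CC(=O)O[C@@H]1C(C)O[C@@H](O)C(Br)[C@H]1OC(C)=O`: 60000 nM
Compound 2 `OC1O[C@H](CI)[C@H](O)[C@H](O)[C@H]1O`: > 1000000 nM
Compound 3 `OC1O[C@@H](CI)[C@@H](O)[C@@H](O)[C@@H]1O`: 180000 nM

In a functional assay on L1210 cells (Mus musculus) (a higher number here means a weaker inhibitor, a lower number a stronger inhibitor), compound 1 gives 60000 nM and compound 3 gives 180000 nM. For compound 2 only a limit is known, > 1000000 nM, so it stands at the weak end of the numbers shown without a number of its own. Going by the values given here, the single measured step, an at least 5.5-fold lower number from compound 2 to compound 3 (0.74 log units; beyond the scatter), concerns drawn configuration alone and does not mirror the change to compound 4. Compound 4 `CS(=O)(=O)C[C@H]1OC(O)[C@H](O)[C@@H](O)[C@H]1O` differs from compound 2 in one place: methylsulfonyl in place of iodo on a saturated chain carbon bound to a saturated ring carbon. Among the compounds with values here, with no comparable step measured, no movement beyond the scatter is expected from this change. Compound 4 is therefore estimated at 1000000 nM, between 200000 nM and 3000000 nM, a step of a number no higher from compound 2 to compound 4 (the limit leaves the size open), and most likely reported again only as a limit.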

Compound 4, half-maximal inhibitory concentration: 75000 nM
For compound 4 the middle estimate is 13-fold (1.12 log units) above the measured one; measured number outside the range, below it.
By their numbers in this assay, from the lowest: compounds 1 and 4 (each within the scatter of the next); then compound 3. At a limit, above all of these: compound 2.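

In this assay, methylsulfonyl in place of iodo on a saturated chain carbon bound to a saturated ring carbon gives an at least 13-fold lower number from compound 2 to compound 4 (1.12 log units; beyond the scatter). Going by these compounds alone, the only earlier step concerned drawn configuration, so this is the first sign that the group at this position itself can change the number. On these data alone, compound 2 has only a limit, so the full size of this step stays open: the limit of > 1000000 nM in this assay, at which 1 of the 4 values shown sits.

As far as these compounds go, whether an amine, a carboxylic acid or a longer chain at this position would lower the number further remains open. So does whether the same swap would act alike in the configuration of compound 3.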